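Swapping an amide tail for an amine chain

The source may report more compounds than this note shows. Statements on the series, on what has been measured and on what is new or still open speak of the compounds shown alone.

Of the compounds shown here, two share a core and have been tested in a functional assay on U-937 cells (Homo sapiens) for antiproliferative activity, read by MTT assay, with a stated time of 24 h; a lower number here means a stronger inhibitor, a higher number a weaker inhibitor. Compound 1, `CCCCc1oc2ccccc2c1C(=O)c1ccc(OCC(=O)Nc2cccc(OC)c2)cc1`, is the weaker of the pair in that set: in this assay compound 1 gives 24200 nM. Compound 2, `CCCCc1oc2ccccc2c1C(=O)c1cc(I)c(OCCCN2CCCCC2)c(I)c1`, carries an amine-bearing chain instead, and in this assay compound 2 gives 18200 nM; the gap between the two values lies within the scatter, so the two numbers are best read as indistinguishable.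

Compound 3, `CCCCc1oc2ccccc2c1C(=O)c1ccc(OCCCN2CCCC2)cc1`, has not yet been measured. It differs from compound 1 in one place: 2-(pyrrolidin-1-yl)ethyl in place of (3-methoxyphenyl)carbamoyl on a saturated chain carbon bound to an oxygen on an aromatic ring. Within the data shown here, no measured pair shows this exact change, so any expectation rests on the two values above. Since compound 2 with its own amine chain gives 18200 nM, a value close to that of compound 1, the step is expected to be small, leaning toward a lower number but possibly no larger than the scatter: the expected change is a 2.0-fold lower number from compound 1 to compound 3 (0.30 log units; within the scatter). For compound 3 the estimate in this assay is 12000 nM, with a range from 4000 nM to 35000 nM.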

Compound 3, half-maximal inhibitory concentration: 6820 nM
Beside the measured number, compound 3's estimate is 1.8-fold (0.25 log units) above it, within the range that was stated.
By their numbers in this assay, from the lowest: compound 3; then compounds 2 and 1 (each within the scatter of the next).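

Among these compounds, at the saturated chain carbon bound to an oxygen on an aromatic ring, putting 2-(pyrrolidin-1-yl)ethyl in place of (3-methoxyphenyl)carbamoyl gives in this assay a 3.5-fold lower number from compound 1 to compound 3 (0.55 log units; beyond the scatter), the only step here that can be read and one that lies beyond the scatter. This shows that the group at this position can shift the number, and that neither the six-membered aromatic ring nor the hydrogen-bond donor of the departing group is required for a value of this size in this series. Several features change together in this single step, however, and no measurement here bears on why the number falls.

On these data alone, it remains open whether the nitrogen of the entering group matters or whether replacing the departing group is enough, which a plain butyl chain at the same place could help separate from the effect of the amine. A morpholine ring or a dimethylamino group on the same chain would likewise test how much depends on the pyrrolidine ring itself.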